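Urea ethyl for phenyl swap, HT-29 series

The compounds below may be only part of what the source reports. "The series", "measured", "known", "first", "only" and "open" are said of these compounds alone.

Measured in a functional assay on HT-29 cells (Homo sapiens) for cytotoxicity; a lower number here means a stronger inhibitor, a higher number a weaker inhibitor:
- compound 1 `Cc1n[nH]c2nnc(N)c-2c1C`: > 100000 nM
- compound 2 `O=C(Nc1ccccc1)Nc1[nH]nc2nnc(-c3ccccc3)c(-c3ccccc3)c12`: > 100000 nM

Compound 2 gives > 100000 nM, which is a limit of the assay and not a number. Compound 1 gives > 100000 nM, which is also a limit. The whole of the measured picture is therefore (the limit of > 100000 nM in this assay, at which 2 of the 2 values shown sit). For the measured compounds named here, the two compounds offer no measured step, so the data do not show how much any structural change moves this assay.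

The next compound, compound 3 `CCNC(=O)Nc1[nH]nc2nnc(-c3ccccc3)c(-c3ccccc3)c12`, keeps the core of compound 2 and has ethyl in place of phenyl on an amide-type nitrogen. The expectation rests on compound 2 with its > 100000 nM, and on nothing more specific. No step beyond the scatter is expected in either direction, and a gain in strength would be a surprise. The expected step is a number no higher from compound 2 to compound 3 (the limit leaves the size open). For compound 3 the estimated value is 100000 nM, with an expected range from 30000 nM to 150000 nM, and a further report as a limit is the likeliest outcome.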

Compound 3, half-maximal inhibitory concentration: > 100000 nM
Compound 3 ended at the assay's limit; the forecaster's own chance of this, stated with the estimate: 75%; the middle value sits exactly at the limit.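

In this assay compound 3 gives > 100000 nM, a limit of the assay and not a number. Compound 2 also sits at a limit, and no step can be read for ethyl in place of phenyl between compound 2 and compound 3. The compounds shown leave open which structural change, if any, would give a measurable value in this assay.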